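Side-chain configuration on a shared cytotoxic core

This account rests on a few compounds, and the source may have more. Where it says the series, first, only, none or still open, it means among the compounds named here.

Measured so far, in a functional assay on A-375 cells (Homo sapiens) for cytotoxicity, read by MTT assay, with a stated time of 72 h; a higher number here means a weaker inhibitor, a lower number a stronger inhibitor:
Compound 1 `O=C1c2c[n+]([O-])c3ccccc3c2C(=O)c2c1c1ccccc1n2Cc1cn(C[C@H](O)CO)nn1` gives 350 nM.
Compound 2 `O=C1c2c[n+]([O-])c3ccccc3c2C(=O)c2c1c1ccccc1n2Cc1cn([C@H]2C[C@H](O)[C@@H](CO)O2)nn1` gives 390 nM.
Compound 3 `CN(C)CCCCn1c2c(c3ccccc31)C(=O)c1c[n+]([O-])c3ccccc3c1C2=O` gives 470 nM.

All three carry the same core and differ only in the group on the aromatic nitrogen. Compound 1 has the lowest of the three numbers, but neither neighbour is separated from it by more than the scatter: a 1.1-fold higher number from compound 1 to compound 2 (0.05 log units; within the scatter), and a 1.3-fold higher number from compound 1 to compound 3 (0.13 log units; within the scatter). No order among the three can therefore be read from these values.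

Compound 4 `O=C1c2c[n+]([O-])c3ccccc3c2C(=O)c2c1c1ccccc1n2Cc1cn(C[C@@H](O)CO)nn1` is the next case. Its relation to compound 1: the two compounds have the same atoms and bonds and differ only in configuration as drawn: 1 of 1 stereo elements differ; a stereocentre at a saturated chain carbon is drawn S in compound 1 and R in compound 4.

Both measured steps bear on this. Each swapped out the entire substituent on the chain carbon bound to the aromatic nitrogen, or the entire group on the triazole nitrogen, and each stayed within the scatter. The change from compound 1 to compound 4 touches the same region but alters nothing except the drawn configuration of one stereocentre, which is a smaller change than either measured step. The expected step is a 1.1-fold higher number from compound 1 to compound 4 (0.02 log units; within the scatter), none beyond the scatter.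

For compound 4 in this assay the estimate is 370 nM, with an expected range of 180 nM to 760 nM.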

Compound 4, half-maximal inhibitory concentration: 140 nM
The estimate for compound 4 lay 2.6-fold (0.42 log units) above the measured number; measured number outside the range, below it.
By their numbers in this assay, from the lowest: compound 4; then compounds 1, 2 and 3 (each within the scatter of the next).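

In this assay, for the compounds shown here, the stereocentre at a saturated chain carbon gives the first change to go beyond the scatter, with a 2.5-fold lower number from compound 1 to compound 4 (0.40 log units; beyond the scatter) and with nothing else to account for it: the fact that compounds 1 and 4 differ only in the configuration as drawn. The replacements of the whole group had stayed within the scatter of compound 1, yet the same 2,3-dihydroxypropyl group drawn R also stands apart from the other two side chains, with a 2.8-fold lower number from compound 2 to compound 4 (0.44 log units; beyond the scatter) and with a 3.4-fold lower number from compound 3 to compound 4 (0.53 log units; beyond the scatter) as the further step. The flat picture given by compounds 1, 2 and 3 therefore does not extend to compound 4, and at this position configuration has to be counted as a variable in its own right.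

From the compounds shown here alone, it stays open whether the lower number of the R form survives when a hydroxyl of the 2,3-dihydroxypropyl group gives way to a methoxy group or a carboxylic acid. Going by these compounds, it also stays open whether a longer chain carrying the same stereocentre shows a difference of this size between its R and S forms.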